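The source may hold more compounds than are shown below. What is called first, only, known or untested is meant among the compounds shown, and "the series" means these compounds.

The three measured compounds and their results in a functional assay on A-375 cells (Homo sapiens) for antiproliferative activity, read by trypan blue exclusion, with a stated time of 48 h, tested at 1 uM; a higher number here means a weaker effect of the compound at the concentration tested, a lower number a stronger effect:

- compound 1, `CCCCCCC#Cc1ccc(S(=O)(=O)Nc2cccc(-c3csc(NC(C)=O)n3)c2)cc1`: 40.7%
- compound 2, `CCCCC#Cc1ccc(S(=O)(=O)Nc2cccc(-c3csc(NC(C)=O)n3)c2)cc1`: 73.2%
- compound 3, `CC(=O)Nc1nc(-c2cccc(NS(=O)(=O)c3ccc(C#CCCc4ccccc4)cc3)c2)cs1`: 11.5%

Compound 3 stands lowest of the three numbers in this assay, which here means the strongest effect; its nearest neighbour is compound 1 and its furthest is compound 2. Compound 4, `CCCCCCCCc1ccc(S(=O)(=O)Nc2cccc(-c3csc(NC(C)=O)n3)c2)cc1`, differs from compound 3 in one place: octyl in place of 4-phenylbut-1-yn-1-yl on an aromatic carbon. Among the measured compounds shown here, two measured steps bear on this. From compound 1 to compound 3 the phenyl entered and the effect strengthened, a number 29.2 percentage points lower from compound 1 to compound 3 (beyond the scatter), so taking the phenyl away again should give most of that back. For the measured compounds named here, from compound 1 to compound 2 the chain was shortened and the effect weakened, a number 32.5 percentage points higher from compound 1 to compound 2 (beyond the scatter), so chain length appears to matter; the octyl chain of compound 4 is as long as the chain of compound 1, but the triple bond is gone, and no measured step speaks to that loss. Compound 4 is therefore expected to land near compound 1 rather than near compound 3. Relative to compound 3, the expected step for compound 4 is a number 33.5 percentage points higher from compound 3 to compound 4 (beyond the scatter). The estimate for compound 4 in this assay is 45%, within 20% to 75%.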

Compound 4, a percentage reported as activity, at one concentration (the size of the read-out at that concentration, not a potency): 34.8%
Compound 4: middle estimate off by 10.2 percentage points, on the high side; measured number inside the range.
By their numbers in this assay, from the lowest: compound 3; then compounds 4 and 1 (each within the scatter of the next); then compound 2.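

In this assay, octyl in place of oct-1-yn-1-yl gives a number 5.9 percentage points lower from compound 1 to compound 4 (within the scatter), so at this chain length the triple bond can be removed with no change beyond the usual spread of repeat measurements. Octyl in place of hex-1-yn-1-yl gives a number 38.4 percentage points lower from compound 2 to compound 4 (beyond the scatter), but this step alters both chain length and the triple bond, so it cannot separate the two. Octyl in place of 4-phenylbut-1-yn-1-yl gives a number 23.3 percentage points higher from compound 3 to compound 4 (beyond the scatter), leaving compound 3 with the strongest effect of the four compounds.

Still open, from the compounds shown here alone, is whether hexyl would match hex-1-yn-1-yl, and whether 4-phenylbutyl would keep the effect of compound 3 without the triple bond. No measurement here gives a reason for these differences.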